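Notes on the aniline substituent series

This account rests on a few compounds, and the source may have more. Where it says the series, first, only, none or still open, it means among the compounds named here.

The three measured compounds share one core and differ only in the substituent on the aniline ring. Compound 1 `C=CC(=O)Nc1cccc(NC(=O)CSc2nc(Nc3ccccc3)c3ccccc3n2)c1` gives 8120 nM in a functional assay on NCI-H1975 cells (Homo sapiens) for inhibition, read by MTT assay, with a stated time of 72 h; on this read-out lower numbers stand for stronger inhibition and higher numbers for weaker inhibition. Compound 2 `C=CC(=O)Nc1cccc(NC(=O)CSc2nc(Nc3cccc(Cl)c3)c3ccccc3n2)c1` gives 9460 nM in this assay, and compound 3 `C=CC(=O)Nc1cccc(NC(=O)CSc2nc(Nc3cccc(OC)c3)c3ccccc3n2)c1` gives 7940 nM. Compound 3 holds the low end of the three numbers, but the steps of a 1.0-fold lower number from compound 1 to compound 3 (0.01 log units; within the scatter) and a 1.2-fold lower number from compound 2 to compound 3 (0.08 log units; within the scatter) both sit within the scatter, as does a 1.2-fold higher number from compound 1 to compound 2 (0.07 log units; within the scatter), so nothing separates these three compounds in this assay.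

Compound 4 `C=CC(=O)Nc1cccc(NC(=O)CSc2nc(Nc3cc(OC)c(OC)c(OC)c3)c3ccccc3n2)c1` is not yet measured. It differs from compound 3 by 3,4,5-trimethoxyphenyl in place of 3-methoxyphenyl on a nitrogen on an aromatic ring. The measured steps that bear on this are the ones that place a single methoxy on the same ring, a 1.0-fold lower number from compound 1 to compound 3 (0.01 log units; within the scatter) and a 1.2-fold lower number from compound 2 to compound 3 (0.08 log units; within the scatter), and both are flat. Within the data shown here, no measured step adds more than one methoxy, so the two further methoxy groups in compound 4 have no precedent in this set. The step expected on these data, a 1.0-fold higher number from compound 3 to compound 4 (0.00 log units; within the scatter), is none beyond the scatter, with the range widened for the untested part of the change. Compound 4 is therefore estimated at 8000 nM in this assay, within 3500 nM to 18000 nM.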

Compound 4, half-maximal inhibitory concentration: > 50000 nM
Compound 4 gave a limit, no number; the forecaster's own chance of this, stated with the estimate: 5%; middle value at least 6.2-fold (0.79 log units) away from the limit.
By their numbers in this assay, from the lowest: compounds 3, 1 and 2 (each within the scatter of the next). At a limit, above all of these: compound 4.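

The aniline position is not indifferent to every change. In this assay compound 4 stands at a limit of the assay and not at a number: the limit of > 50000 nM in this assay, at which 1 of the 4 values shown sits. Phenyl, 3-chlorophenyl and 3-methoxyphenyl stay within the scatter of one another, whereas 3,4,5-trimethoxyphenyl, with 12 heavy atoms and 3 hydrogen-bond acceptors against 8 and 1 for 3-methoxyphenyl, is the first group here to separate from the others, with all three steps beyond the scatter: an at least 6.2-fold higher number from compound 3 to compound 4 (0.79 log units; beyond the scatter) and an at least 5.2-fold higher number from compound 2 to compound 4 (0.72 log units; beyond the scatter) and an at least 6.1-fold higher number from compound 1 to compound 4 (0.78 log units; beyond the scatter) (each of them a minimum, its full size unknown).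

The compounds shown leave open whether one further methoxy, as in a dimethoxyphenyl group, already produces this separation or whether it takes the full 3,4,5-trimethoxyphenyl pattern. They also leave open how the position responds to groups of another kind on the same ring, such as an amine or a carboxylic acid, and whether any group there can bring the number below the flat level of compounds 1, 2 and 3.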